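Swapping a saturated ring for a pyrazine on the piperazine

This account rests on a few compounds, and the source may have more. Where it says the series, first, only, none or still open, it means among the compounds named here.

Compound 1 `Nc1ccccc1NC(=O)c1ccc(CSC(=S)N2CCN(c3ccc(F)cc3)CC2)cc1` and compound 2 `Nc1ccccc1NC(=O)c1ccc(CSC(=S)N2CCN(C3CCCCC3)CC2)cc1` share one core and differ only at the amine nitrogen of the six-membered ring. In a functional assay on A-375 cells (Homo sapiens) for antiproliferative activity, read by CCK-8 assay, with a stated time of 72 h, tested at 8 uM (a higher number here means a stronger effect of the compound at the concentration tested, a lower number a weaker effect), compound 1 gives 76.3%, and in this assay compound 2 gives 89.9%. The step of a number 13.6 percentage points higher from compound 1 to compound 2 (beyond the scatter) is the only one measured, so compound 2 stands highest of the two numbers, with compound 1 as its nearest neighbour.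

Compound 3 `Nc1ccccc1NC(=O)c1ccc(CSC(=S)N2CCN(c3cnccn3)CC2)cc1` changes the same position again: pyrazin-2-yl in place of cyclohexyl on an amine nitrogen in a ring. Within the data shown here, the one measured step bears on this directly, since it shows that replacing an aromatic ring by cyclohexyl raised the read-out by a modest amount. Reversing that direction, from cyclohexyl back to an aromatic ring, is therefore expected to lower the number by a comparable amount, though a pyrazine is not a fluorophenyl and the step could be smaller. Compound 3 is expected to give 78%, most likely between 62% and 92%, a step of a number 11.9 percentage points lower from compound 2 to compound 3 (beyond the scatter) that is estimated to fall just beyond the scatter.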

Compound 3, a percentage reported as inhibition, at one concentration (the size of the read-out at that concentration, not a potency): 85.8%
Estimate against measurement, compound 3: 7.8 percentage points below; low and high end bracket the measured number.
By their numbers in this assay, from the lowest: compounds 1, 3 and 2 (each within the scatter of the next, the first and the last beyond it).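

In this assay, the step of a number 4.1 percentage points lower from compound 2 to compound 3 (within the scatter) shows that pyrazin-2-yl can take the place of cyclohexyl on this amine nitrogen in a ring with no difference that stands out from the scatter. The step of a number 9.5 percentage points higher from compound 1 to compound 3 (within the scatter) shows the same for pyrazin-2-yl against 4-fluorophenyl, so an aromatic ring here does not by itself separate a compound from cyclohexyl: only compound 1 and compound 2 lie beyond the scatter of each other, and compound 3 lies within the scatter of both. No available evidence bears on what lies behind these numbers.

On these data alone, what a methyl group or a longer carbon chain would give at this position remains open. The read-out gives the size of the effect at a single concentration only, so it also leaves open whether compound 2 and compound 3 would stay this close at other concentrations.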